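A few compounds are considered here, and "the series" means these few. Any claim that something is new, unique, unknown or untested is made for them only; others in the source may bear on it.

Working notes on the series. Among the measured compounds shown here, compound 3 `CCc1cccc2c(OC)c(-c3occ(C)c3COCC(F)(F)F)ccc12` is the only member with a number in a functional assay on SK-BR-3 cells (Homo sapiens) for cytotoxicity, read by MTT assay, with a stated time of 72 h (a higher number here means that more compound is needed for the effect, a lower number that less compound is needed), giving 5.3 ug/mL. Compound 1 `CCc1cccc2c(OC(C)=O)c(-c3occ(C)c3COC(C)=O)ccc12` reaches only a limit in this assay, > 10 ug/mL. Compound 2 `CCOCc1c(C)coc1-c1ccc2c(CC)cccc2c1OC` likewise reaches only a limit, > 10 ug/mL. Compound 4 `CCc1cccc2c(OC)c(-c3occ(C)c3COC(C)=O)ccc12` is not yet measured; it differs from compound 3 by acetyl in place of 2,2,2-trifluoroethyl on an oxygen on a saturated carbon. For the measured compounds named here, the one measured step at this oxygen is an at least 1.8-fold lower number from compound 2 to compound 3 (0.27 log units; that floor lies within the scatter), and it ends at the limit (the limit of > 10 ug/mL in this assay, at which 2 of the 3 values shown sit), so its true size is unknown. Compound 1 carries the same acetoxymethyl group as compound 4 and sits at that limit, though it also differs at the core. The step from compound 3 to compound 4 is therefore expected to move the number back upward, estimated as a 1.7-fold higher number from compound 3 to compound 4 (0.23 log units; within the scatter). For compound 4 the estimate is 9 ug/mL, within 4 ug/mL to 20 ug/mL.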

Compound 4, concentration for half-maximal effect: > 10 ug/mL
Compound 4: only a limit was reported; the forecaster's own chance of this, stated with the estimate: 50%; middle value at least 1.1-fold (0.04 log units) from the limit.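

In this assay, acetyl in place of 2,2,2-trifluoroethyl on this oxygen gives an at least 1.8-fold higher number from compound 3 to compound 4 (0.27 log units; that floor lies within the scatter). Compound 4 keeps the shared core of compound 3, so it shows the acetoxy group reaching the limit without the core change that clouded compound 1. The true size of the step stays unknown, and the steps from compound 1 and compound 2 to compound 4 cannot be read, as both ends sit at a limit: the limit of > 10 ug/mL in this assay, at which 3 of the 4 values shown sit.

Still open, going by these compounds, is whether 2,2,2-trifluoroethoxy is needed for a measurable number. A longer fluorinated chain or an amine on this oxygen could test that.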